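Adding an amino group to an inactive amide

A few compounds are considered here, and "the series" means these few. Any claim that something is new, unique, unknown or untested is made for them only; others in the source may bear on it.

Compound 1 `CCCCCCCCC(=O)NCc1cccc(OC)c1`: > 100000 nM (a limit)
Compound 2 `CCCCCCCCC(=O)NCc1ccccc1OC`: > 100000 nM (a limit)
Compound 3 `CCCCCCCCC(=O)NCc1ccc(O)cc1OC`: > 100000 nM (a limit)

In a functional assay with Rattus norvegicus as the target (on this read-out higher numbers stand for an effect only at larger amounts of compound and lower numbers for an effect already at smaller amounts), compound 1 gives > 100000 nM, which is a limit of the assay and not a number. The same holds for the other two measured compounds, so the evidence is simply (the limit of > 100000 nM in this assay, at which 3 of the 3 values shown sit). None of the three therefore has a true number to compare.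

Compound 4 `CCCCCCCCC(=O)NCc1ccc(N)c(OC)c1` is compound 1 with one change: amino in place of hydrogen on an aromatic carbon. The amino group replaces a hydrogen on an aromatic carbon, ortho to a methoxy group and para to a large group.

The closest measured change is a step that the two limits leave unreadable from compound 2 to compound 3, where hydroxy replaces hydrogen. It involves a different group on a different parent compound, so it offers only a weak guide and gives no size to carry over. Compound 3 still shows > 100000 nM, so the expectation stays cautious: compound 4 may well remain at the limit in this assay, and any readable change could only be towards lower numbers.

For compound 4 the estimated value is 30000 nM, with an expected range of 5000 nM to 100000 nM. This estimate means an expected at least 3.3-fold lower number from compound 1 to compound 4 (0.52 log units; beyond the scatter).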

Compound 4, half-maximal effective concentration: > 10000 nM
Compound 4 was reported as a limit (the forecaster's own chance of this, stated with the estimate: 55%); the middle value is on the limit's open side.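

In this assay compound 4 gives > 10000 nM, which is a limit of the assay and not a number. Compound 1 also has only a limit, so the step between compound 1 and compound 4 cannot be read. Whether the amino group changes the effect at all stays open, as all four compounds shown carry only limits.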